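Swapping the Aryl Group: From Compound 2 to Compound 3

A few compounds are considered here, and "the series" means these few. Any claim that something is new, unique, unknown or untested is made for them only; others in the source may bear on it.

Compound 1 `CCC1=C(O)c2c(oc(-c3ccc(OC)cc3)cc2=O)C(CC)(CC)C1=O`: 0.68 uM
Compound 2 `CCC1=C(O)c2c(oc(-c3ccc(C)cc3C)cc2=O)C(CC)(CC)C1=O`: 8.52 uM

Among the compounds with values here, in a functional assay on KBVIN cells (Homo sapiens) for antiproliferative activity, read by sulforhodamine B assay, with a stated time of 3 days (a lower number here means that less compound is needed, a higher number that more compound is needed for the effect), compound 2 stands highest of the two measured compounds, the only step being a 13-fold higher number from compound 1 to compound 2 (1.10 log units; beyond the scatter). Compound 3 `CCC1=C(O)c2c(oc(-c3ccc(F)c(C)c3)cc2=O)C(CC)(CC)C1=O` differs from compound 2 by 4-fluoro-3-methylphenyl in place of 2,4-dimethylphenyl on an aromatic carbon. Within the data shown here, no measured step exchanges a methyl for fluorine, so the aryl change a 13-fold higher number from compound 1 to compound 2 (1.10 log units; beyond the scatter), which was large, is the only guide, and it suggests the aryl group matters strongly here. For compound 3 a moderate move back toward lower numbers is expected, a 2.8-fold lower number from compound 2 to compound 3 (0.45 log units; beyond the scatter). Compound 3 is estimated at 3 uM, in a range from 0.9 uM to 10 uM.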

Compound 3, concentration for half-maximal effect: 1.62 uM
Beside the measured number, compound 3's estimate is 1.9-fold (0.27 log units) above it; low and high end bracket the measured number.
By their numbers in this assay, from the lowest: compound 1; then compound 3; then compound 2.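

In this assay, this position on the ring is not limited to one workable aryl group: 4-fluoro-3-methylphenyl gives a 5.3-fold lower number from compound 2 to compound 3 (0.72 log units; beyond the scatter) and so regains much of the ground lost with 2,4-dimethylphenyl. It does not fully match 4-methoxyphenyl, with a 2.4-fold higher number from compound 1 to compound 3 (0.38 log units; beyond the scatter) showing that the new group falls between the other two. No evidence here explains this order.

Still open, on these data alone, is whether the fluorine or the different methyl placement carries the step. As far as these compounds go, how an aryl group bearing an amine or a carboxylic acid would behave also remains unknown.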